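The source may report more compounds than this note shows. Statements on the series, on what has been measured and on what is new or still open speak of the compounds shown alone.

In a functional assay on Lewis lung carcinoma cells for cytotoxicity against Lewis lung carcinoma cell line (Mus musculus), read by MTT assay, with a stated time of 72 h (a higher number here means a weaker inhibitor, a lower number a stronger inhibitor), compound 1 (`O=C1/C(=C/c2ccccc2)COC/C1=C\c1ccccc1F`) gives 16000 nM and compound 2 (`O=C1/C(=C/c2cccc(O)c2)COC/C1=C\c1ccccc1F`) gives 13800 nM, so these two values sit within the scatter of each other. Compound 3 (`O=C1/C(=C/c2ccccc2F)COC/C1=C\c1ccc(Cl)cc1Cl`) differs from compound 2 on a double-bonded chain carbon bound to a double-bonded ring carbon: 2,4-dichlorophenyl in place of 3-hydroxyphenyl on a double-bonded chain carbon bound to a double-bonded ring carbon. Going by the values given here, the only measured step, a 1.2-fold lower number from compound 1 to compound 2 (0.06 log units; within the scatter), stays within the scatter and involves hydroxy in place of hydrogen, so it offers weak guidance, and no measured compound carries chlorine. A modest step is expected in this assay, tentatively toward a lower number: the estimated step is a 1.5-fold lower number from compound 2 to compound 3 (0.19 log units; within the scatter). For compound 3 the estimated value is 9000 nM, with an expected range of 3500 nM to 20000 nM.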

Compound 3, half-maximal inhibitory concentration: 29400 nM
Compound 3: the middle estimate sits 3.3-fold (0.51 log units) below what was measured, outside the stated range (above it).
By their numbers in this assay, from the lowest: compounds 2, 1 and 3 (each within the scatter of the next, the first and the last beyond it).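

Going by these compounds alone, at this place, on a double-bonded chain carbon bound to a double-bonded ring carbon, 2,4-dichlorophenyl in place of 3-hydroxyphenyl gives a 2.1-fold higher number from compound 2 to compound 3 (0.33 log units; beyond the scatter) in this assay, the first step beyond the scatter, though a modest one. 2,4-dichlorophenyl in place of phenyl gives a 1.8-fold higher number from compound 1 to compound 3 (0.26 log units; within the scatter), so only the step from 3-hydroxyphenyl clears the scatter. Nothing available accounts for either step. Open, as far as these compounds go, is whether an amine or a carboxylic acid on the ring here would give a lower number, and whether 4-chlorophenyl would behave like 2,4-dichlorophenyl.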